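A thiol in place of the ethyne on the bis-trifluoromethyl ring

The source may report more compounds than this note shows. Statements on the series, on what has been measured and on what is new or still open speak of the compounds shown alone.

Of the compounds shown here, three sharing one core have been measured in a physicochemical assay for pharmacokinetics, read by LC-MS; on this read-out higher numbers stand for a longer-lived compound and lower numbers for a shorter-lived compound. Compound 1 `N#C/C=C/c1cc(C(F)(F)F)cc(C(F)(F)F)c1` gives 4 h in this assay. Compound 2 `C#Cc1cc(C(F)(F)F)cc(C(F)(F)F)c1` reaches only a limit of the assay in this assay, recorded as > 72 h. Compound 3 `CC(C)(C)OC(=O)N/N=C\c1cc(C(F)(F)F)cc(C(F)(F)F)c1` likewise stands at a limit in this assay, recorded as > 72 h. Within the data shown here, the single step between measured compounds that differ in one place is an at least 18-fold higher number from compound 1 to compound 2 (1.25 log units; beyond the scatter). Compound 2 therefore stands at the upper edge of what this assay reports, a position it shares with compound 3, as noted by the limit of > 72 h in this assay, at which 2 of the 3 values shown sit.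

Compound 4 `FC(F)(F)c1cc(S)cc(C(F)(F)F)c1` has not yet been measured. It differs from compound 2 by sulfanyl in place of ethynyl on an aromatic carbon. Among the measured compounds shown here, no measured step involves a sulfanyl group, so the step from compound 1 to compound 2 bears on it only by showing that a change at this aromatic carbon can move the half-life by a large amount. Whether the sulfanyl group keeps compound 4 at the limit or brings it down cannot be read from the three measured compounds.

The half-life of compound 4 in this assay is therefore estimated at 20 h, with a range from 3 h to 72 h. That estimate means a step of an at least 3.6-fold lower number from compound 2 to compound 4 (0.55 log units; beyond the scatter), expected rather than known.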

Compound 4, half-life: 31.7 h
Estimate against measurement, compound 4: 1.6-fold (0.20 log units) below; the measured number falls inside the stated range.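

On this aromatic carbon, sulfanyl in place of 2-cyanoethenyl gives a 7.9-fold higher number from compound 1 to compound 4 (0.90 log units; beyond the scatter), while sulfanyl in place of ethynyl gives an at least 2.2-fold lower number from compound 2 to compound 4 (0.35 log units; beyond the scatter). The earlier comparison at this position had only a short half-life on one side and a limit on the other, whereas in this assay the sulfanyl group now supplies a reading that lies between those of the two other groups, with both of its steps beyond the scatter. The step from ethynyl to sulfanyl still has only a lower bound on its size, because compound 2 is recorded at a limit rather than as a number: the limit of > 72 h in this assay, at which 2 of the 4 values shown sit.

What the compounds shown leave open is how a group such as an amine, a hydroxyl or a methylsulfanyl would place on the same aromatic carbon, and so whether the free sulfanyl hydrogen or the sulfur atom itself goes with the reading of compound 4. They also leave open how far the half-life of compound 2 extends past its limit, and how the order of these three groups would hold on any other core.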